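The compounds below may be only part of what the source reports. "The series", "measured", "known", "first", "only" and "open" are said of these compounds alone.

Measured compounds:
compound 1, `O=c1cc(/C=C/c2ccc([N+](=O)[O-])cc2)[nH]cc1O`, in a functional assay, with a stated time of 10 min (a lower number here means a stronger inhibitor, a higher number a weaker inhibitor), gives 4790 nM;
compound 2, `CCOc1ccc(/C=C/c2cc(=O)c(O)c[nH]2)cc1`, in this assay gives 8120 nM;
compound 3, `Cn1cc(O)c(=O)cc1/C=C/c1ccc([N+](=O)[O-])cc1`, in this assay gives 19200 nM.

Compound 4, `CCOc1ccc(/C=C/c2cc(=O)c(O)cn2C)cc1`, has not yet been measured in this assay. It is related to compound 3 by ethoxy in place of nitro on an aromatic carbon, the same change that relates compound 1 to compound 2, namely (ethoxy in place of nitro on an aromatic carbon). That change was made once among the measured compounds and produced a 1.7-fold higher number from compound 1 to compound 2 (0.23 log units; within the scatter). The two cores on which the change is made differ by methyl in place of hydrogen on an aromatic nitrogen, a change that produced a 4.0-fold higher number from compound 1 to compound 3 (0.60 log units; beyond the scatter), so compound 3 stands at the highest number of the three.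

Because compound 1 to compound 2 gave a 1.7-fold higher number from compound 1 to compound 2 (0.23 log units; within the scatter), a step of similar size is expected from compound 3 to compound 4, namely a 1.6-fold higher number from compound 3 to compound 4 (0.21 log units; within the scatter). This rests on a single earlier instance of the change, so the expectation is held loosely. Compound 4 is thus expected to give about 31000 nM in this assay, estimated to lie between 12000 nM and 80000 nM.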

Compound 4, half-maximal inhibitory concentration: 4020 nM
Estimate against measurement, compound 4: 7.7-fold (0.89 log units) above; measured number below the stated range.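

In this assay, ethoxy in place of nitro on an aromatic carbon gave a 4.8-fold lower number from compound 3 to compound 4 (0.68 log units; beyond the scatter), so on the core with methyl on the aromatic nitrogen this change did not behave as it did on the core of compound 1: the same change on two cores in this assay, a 1.7-fold higher number (0.23 log units; within the scatter) from compound 1 to compound 2 and a 4.8-fold lower number (0.68 log units; beyond the scatter) from compound 3 to compound 4, 8.1-fold (0.91 log units) apart, beyond the scatter of two such steps. Read the other way, methyl in place of hydrogen on an aromatic nitrogen gave a 2.0-fold lower number from compound 2 to compound 4 (0.31 log units; beyond the scatter), so the outcome of that change also depended on whether the compound carried nitro or ethoxy: the same change on two cores in this assay, a 4.0-fold higher number (0.60 log units; beyond the scatter) from compound 1 to compound 3 and a 2.0-fold lower number (0.31 log units; beyond the scatter) from compound 2 to compound 4, 8.1-fold (0.91 log units) apart, beyond the scatter of two such steps. Both comparisons rest on the same four compounds, so they show that neither change can be carried from one core to the other at face value in this series, but they do not show why, or whether the same holds for other groups.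

The compounds shown leave open how an amine or a carboxylic acid in place of nitro or ethoxy would behave on either core. They also leave open what a longer chain in place of the methyl on the aromatic nitrogen would do.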